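The compounds below may be only part of what the source reports. "The series", "measured", "known", "first", "only" and "open" are said of these compounds alone.

Values in an assay on microsomes from liver for inhibition of 3-hydroxy-3-methylglutaryl-coenzyme A reductase (Rattus norvegicus) (on this read-out higher numbers stand for weaker inhibition and lower numbers for stronger inhibition), for the three measured compounds:

Compound 1 `CC(C)c1c(C(=O)N(C)Cc2cccc(F)c2)nn(-c2ccc(F)cc2)c1CC[C@@H](O)C[C@@H](O)CC(=O)O` gives 4.1 nM.
Compound 2 `CCN(Cc1ccccc1)C(=O)c1nn(-c2ccc(F)cc2)c(OC[C@@H](O)C[C@@H](O)CC(=O)O)c1C(C)C` gives 14 nM.
Compound 3 `Cc1ccc(CN(C)C(=O)c2nn(-c3ccc(F)cc3)c(OC[C@@H](O)C[C@@H](O)CC(=O)O)c2C(C)C)cc1` gives 37 nM.

Compound 2 sits second highest of these three numbers: compound 1 lies below it, and compound 3 above it, both beyond the usual scatter. The new compound 4 `Cc1ccc(CNC(=O)c2nn(-c3ccc(F)cc3)c(OC[C@@H](O)C[C@@H](O)CC(=O)O)c2C(C)C)cc1` is made from compound 2 by one change on the carbonyl carbon: (4-methylbenzyl)amino in place of benzyl(ethyl)amino on a carbonyl carbon. Among the measured compounds shown here, only one measured step touches this part of the molecule, the change from compound 2 to compound 3, which swapped the same benzyl(ethyl)amino for methyl(4-methylbenzyl)amino and gave a 2.6-fold higher number from compound 2 to compound 3 (0.42 log units; beyond the scatter). Compound 4 goes one step further than compound 3 in the same direction, keeping the 4-methylbenzyl group but removing the remaining alkyl on the nitrogen, so that a hydrogen-bond donor enters. For the measured compounds named here, there is no measured pair that isolates this last removal, so the expectation leans on the one step available and is accordingly uncertain. A modest rise in the number, of about the same size as that step or somewhat larger, is expected from compound 2 to compound 4: a 2.9-fold higher number from compound 2 to compound 4 (0.46 log units; beyond the scatter). For compound 4 in this assay the estimate is 40 nM, with a plausible range from 12 nM to 130 nM.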

Compound 4, half-maximal inhibitory concentration: 15 nM
The estimate for compound 4 lay 2.7-fold (0.43 log units) above the measured number; the range from low to high includes it.
By their numbers in this assay, from the lowest: compound 1; then compounds 2 and 4 (each within the scatter of the next); then compound 3.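

In this assay, the amide nitrogen on this carbonyl carbon does not need a second alkyl group: putting hydrogen in place of methyl gives a 2.5-fold lower number from compound 3 to compound 4 (0.39 log units; beyond the scatter) and so runs against the earlier step, a 2.6-fold higher number from compound 2 to compound 3 (0.42 log units; beyond the scatter). Replacing benzyl(ethyl)amino with (4-methylbenzyl)amino gives a 1.1-fold higher number from compound 2 to compound 4 (0.03 log units; within the scatter), so this exchange, which brings in the amide hydrogen and removes the ethyl, leaves the number within the scatter, and the higher number of compound 3 goes with the methyl-bearing amide rather than with the 4-methylbenzyl group alone. No measurement here explains why the methyl and the hydrogen on this nitrogen give different numbers.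

The compounds shown leave open what the methyl on the benzyl ring contributes by itself, and whether a chlorine atom or a methoxy group in its place would give a similar number. Also open, as far as these compounds go, is whether the same hydrogen-for-methyl change on the nitrogen would give a similar step on the core of compound 1, whose amide carries a 3-fluorobenzyl group.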